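The source may report more compounds than this note shows. Statements on the series, on what has been measured and on what is new or still open speak of the compounds shown alone.

Compound 1, `COc1cc(/C=C/C(=O)C2=C(/C=C/c3ccc(O)c(OC)c3)NC(=S)NC2c2ccc(C)cc2)ccc1O`: in a functional assay, with a stated time of 20 min, tested at 50 uM (on this read-out lower numbers stand for a weaker effect and higher numbers for a stronger effect at the one concentration tested), compound 1 gives 41%.
Compound 2, `COc1cc(/C=C/C(=O)C2=C(/C=C/c3ccc(O)c(OC)c3)NC(=S)NC2c2c(Cl)cccc2Cl)ccc1O`: in this assay compound 2 gives 50%.

Compound 2 stands highest of the two numbers, yet its step of a number 9 percentage points higher from compound 1 to compound 2 (within the scatter) lies within the scatter, so the two cannot be ordered. Compound 3, `COc1cc(/C=C/C(=O)C2=C(/C=C/c3ccc(O)c(OC)c3)NC(=S)NC2c2ccccc2Cl)ccc1O`, is not yet measured. It differs from compound 2 by hydrogen in place of chloro on an aromatic carbon. Among the measured compounds shown here, the only step that bears on this change is the one from compound 1 to compound 2, which swapped the whole aryl group and moved the read-out only within the scatter. A single chloro removed is therefore expected to give a step of a number 4 percentage points lower from compound 2 to compound 3 (within the scatter) in this assay, no larger than the scatter. Compound 3 is estimated at 46%, between 34% and 58%.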

Compound 3, a percentage reported as activity, at one concentration (the size of the read-out at that concentration, not a potency): 55.6%
For compound 3 the middle estimate is 9.6 percentage points below the measured one, and the stated range covers the measured number.
By their numbers in this assay, from the lowest: compounds 1, 2 and 3 (each within the scatter of the next, the first and the last beyond it).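

Taking one chloro off the 2,6-dichlorophenyl group gives a number 5.6 percentage points higher from compound 2 to compound 3 (within the scatter) in this assay and so shows that the read-out holds with a single chloro on this ring. Against the 4-methylphenyl group, the 2-chlorophenyl group gives a number 14.6 percentage points higher from compound 1 to compound 3 (beyond the scatter) and this modest step is the first at this position to pass the scatter. Nothing measured here accounts for that step. The compounds shown leave open how an aryl ring carrying an amine or a carboxylic acid would read in this assay at this position.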